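Shortening the Oxanyl Link on the Amine Nitrogen

The compounds below may be only part of what the source reports. "The series", "measured", "known", "first", "only" and "open" are said of these compounds alone.

Measured in an assay on HEK293 cells for displacement of a labelled ligand from corticotropin-releasing factor receptor 1 (Homo sapiens), with a stated time of 2 h; on this read-out lower numbers stand for stronger inhibition and higher numbers for weaker inhibition:
compound 1, `CCCN(CCC)c1ccc(C)c2nc(-c3c(OC)cc(COC)cc3OC)c(C)cc12`, 88 nM
compound 2, `COCc1cc(OC)c(-c2nc3c(C)ccc(N(C)C)c3cc2C)c(OC)c1`, 212 nM
compound 3, `COCc1cc(OC)c(-c2nc3c(C)ccc(N(CC4CCOCC4)CC4CC4)c3cc2C)c(OC)c1`, 286 nM

Compound 3 gives the highest number of the three. Its gap to compound 1 is beyond the scatter, a 3.3-fold higher number from compound 1 to compound 3 (0.51 log units; beyond the scatter), whereas its gap to compound 2 is not, a 1.3-fold higher number from compound 2 to compound 3 (0.13 log units; within the scatter). The remaining step, a 2.4-fold higher number from compound 1 to compound 2 (0.38 log units; beyond the scatter), is modest.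

Compound 4, `COCc1cc(OC)c(-c2nc3c(C)ccc(N(CC4CC4)C4CCOCC4)c3cc2C)c(OC)c1`, differs from compound 3 in one place: oxan-4-yl in place of (oxan-4-yl)methyl on a nitrogen on an aromatic ring. Among the compounds with values here, none of the measured steps bears directly on this change; each of them replaces the whole substituent set on the nitrogen rather than removing one chain carbon from an (oxan-4-yl)methyl group. The closest guide is that compound 2 and compound 3, which carry quite different groups on that nitrogen, sit within the scatter of each other in this assay, so varied nitrogen substituents of this kind have so far given similar numbers.

The step of a 1.2-fold higher number from compound 3 to compound 4 (0.09 log units; within the scatter) from compound 3 to compound 4 is therefore expected to stay within the scatter, with no clear direction. Compound 4 is estimated at 350 nM in this assay, with a range from 150 nM to 900 nM.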

Compound 4, half-maximal inhibitory concentration: 246 nM
For compound 4 the middle estimate is 1.4-fold (0.15 log units) above the measured one, and the stated range covers the measured number.
By their numbers in this assay, from the lowest: compound 1; then compounds 2, 4 and 3 (each within the scatter of the next).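

In this assay, shortening (oxan-4-yl)methyl to oxan-4-yl on the nitrogen gives a 1.2-fold lower number from compound 3 to compound 4 (0.07 log units; within the scatter) as the only direct reading of this change among the compounds shown, so the read-out does not separate the two forms of the link. The (cyclopropylmethyl)(oxan-4-yl)amino group also keeps level with dimethylamino, with a 1.2-fold higher number from compound 2 to compound 4 (0.06 log units; within the scatter) on that comparison, yet it stays apart from dipropylamino, with a 2.8-fold higher number from compound 1 to compound 4 (0.45 log units; beyond the scatter) as the step, so compound 1 alone now differs beyond the scatter from each of the other compounds. Nothing at hand accounts for why the numbers fall this way.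

Going by these compounds, the shortening has been read only with cyclopropylmethyl as the second group on the nitrogen, so it remains open whether it would read the same with a propyl chain there, or whether a longer (oxan-4-yl)ethyl link or a piperidine ring in place of the oxane ring would move the number. Each step from dipropylamino also replaces both groups on the nitrogen at once, which leaves open how much of that gap belongs to either group alone.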